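The compounds below may be only part of what the source reports. "The series", "measured", "known", "first", "only" and "open" are said of these compounds alone.

Measured so far in a functional assay on HeLa cells (Homo sapiens) for inhibition, read by sulforhodamine B assay; on this read-out higher numbers stand for weaker inhibition and lower numbers for stronger inhibition:
- compound 1 `O=C1C=C(NC2CCCCC2)C(=O)c2c1nc1n2[C@H]2OC[C@@H](O)[C@H]2OC1`: > 16000 nM (a limit)
- compound 2 `O=C1C=C(Nc2ccc(Br)cc2)C(=O)c2c1nc1n2[C@H]2OC[C@@H](O)[C@H]2OC1`: 3830 nM

Compound 1 gives only a limit, > 16000 nM, and not a number. For the measured compounds named here, compound 2, with 3830 nM, holds the only numerical value in this assay, so there is no numerical range against which to place it.

The next compound to read is compound 3 `O=C1C=C(Nc2ccc(C(F)(F)F)cc2)C(=O)c2c1nc1n2[C@H]2OC[C@@H](O)[C@H]2OC1`, which differs from compound 2 by trifluoromethyl in place of bromo on an aromatic carbon. In words, trifluoromethyl replaces bromo on an aromatic carbon, para to a large group.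

Going by the values given here, only one measured step bears on this change, and only indirectly. That step, an at least 4.1-fold lower number from compound 1 to compound 2 (0.62 log units; beyond the scatter), lies beyond the scatter, but it exchanges cyclohexyl for 4-bromophenyl on an amine nitrogen. Among the compounds with values here, no measured pair varies the substituent on the aromatic ring, so the data give no direction for this change. The exchange keeps the aromatic ring in place, and no shift beyond the scatter is expected, so the expected step is a 1.0-fold higher number from compound 2 to compound 3 (0.02 log units; within the scatter). For compound 3 the estimated value is 4000 nM, with an expected range of 1500 nM to 12000 nM.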

Compound 3, half-maximal inhibitory concentration: > 8000 nM
Compound 3 was reported as a limit; the forecaster's own chance of this, stated with the estimate: 12%; middle value at least 2.0-fold (0.30 log units) from the limit.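

In this assay compound 3 is reported only as a limit, > 8000 nM, and not as a number. For the compounds shown here, this is the first change on the aromatic ring itself, on an aromatic carbon para to a large group, and it gives an at least 2.0-fold higher number from compound 2 to compound 3 (0.31 log units; beyond the scatter), so this position does respond to the substituent and the two groups are not interchangeable there: 4-bromophenyl on the amine nitrogen gives a numerical value, while 4-(trifluoromethyl)phenyl gives only a limit. The step between compound 1 and compound 3 cannot be read, as both values are limits.

Going by these compounds alone, the true size of the step to compound 3 stays open, since the limit fixes only its lower bound, and with compound 2 as the sole numerical value the series has no second number against which to judge the substituent. On these data alone, whether bromo is specially favoured at this position or the loss is particular to trifluoromethyl also stays open, and a chloro, methyl or methoxy group at the same carbon, or bromo moved elsewhere on the ring, would be needed to separate the two.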